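The source may report more compounds than this note shows. Statements on the series, on what has been measured and on what is new or still open speak of the compounds shown alone.

Working notes on the series. Compound 1 `CCOC(=O)/C(C#N)=C/c1cc(C)n(-c2cccc(-c3nnn[nH]3)c2)c1C` and compound 2 `Cc1cc(/C=C2\SC(=S)N(c3cccc(C(F)(F)F)c3)C2=O)c(C)n1-c1cccc(-c2nnn[nH]2)c1` share a core and have both been run in an ADME assay on MT2 cells (Homo sapiens) for cytotoxicity, read by XTT assay, with a stated time of 4 days; a lower number here means that less compound is tolerated, a higher number that more compound is tolerated. In this assay compound 1 gives 76800 nM, and in the same assay compound 2 gives 15800 nM. Among the measured compounds shown here, compound 2 therefore holds the lower of the two numbers measured so far, with compound 1 standing higher by a margin beyond the scatter. Compound 3 `Cc1cc(/C=C2\SC(=S)N(c3ccc(C(F)(F)F)cc3)C2=O)c(C)n1-c1cccc(-c2nnn[nH]2)c1` has not yet been measured in this assay. It differs from compound 2 by 4-(trifluoromethyl)phenyl in place of 3-(trifluoromethyl)phenyl on an amide-type nitrogen in a ring, the two compounds holding the same atoms joined differently. For the measured compounds named here, no measured pair in the set shows what this change does, so no step is known. The expectation for a 1.1-fold lower number from compound 2 to compound 3 (0.02 log units; within the scatter) is no step beyond the scatter, in either direction. On that basis compound 3 is estimated at 15000 nM in this assay, with a range from 6000 nM to 40000 nM, pending the actual measurement.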

Compound 3, half-maximal cytotoxic concentration: 27100 nM
Estimate against measurement, compound 3: 1.8-fold (0.26 log units) below; the measured number falls inside the stated range.
By their numbers in this assay, from the lowest: compounds 2 and 3 (each within the scatter of the next); then compound 1.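

In this assay, 4-(trifluoromethyl)phenyl in place of 3-(trifluoromethyl)phenyl on the amide-type nitrogen in the ring gives a 1.7-fold higher number from compound 2 to compound 3 (0.23 log units; within the scatter) for this matched pair. Among the compounds shown here, this is the first reading of any change at this position, and it shows that moving trifluoromethyl between these two places on the phenyl ring does not separate the two compounds in this read-out. The data at hand give no measured basis for explaining the result.

Still open, as far as these compounds go, is whether a group of another kind on this nitrogen, such as an unsubstituted phenyl, a carboxylic acid on the phenyl ring or a plain alkyl chain, would give a step beyond the scatter. Also open, from the compounds shown here alone, is whether the same change would read alike on a different core.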